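The source may report more compounds than this note shows. Statements on the series, on what has been measured and on what is new or still open speak of the compounds shown alone.

Compound 1 `COc1ccc(/C=C/C(=O)c2cc3ccc(OCc4cccc(OC)c4)cc3oc2=O)cc1` and compound 2 `COc1cc(/C=C/C(=O)c2cc3cc(O)ccc3oc2=O)cc(OC)c1OC` share a chalcone-bearing coumarin-type core, and both were tested in a functional assay on K562 cells (Homo sapiens) for cytotoxicity, read by MTT assay, with a stated time of 72 h; on this read-out higher numbers stand for weaker inhibition and lower numbers for stronger inhibition. In this assay compound 1 gives > 100000 nM, which is a limit of the assay rather than a number. Compound 2, by contrast, gives 8800 nM in this assay, so of the two only compound 2 returns a measured value. Where compound 1 stands is therefore fixed only by the limit of > 100000 nM in this assay, at which 1 of the 2 values shown sits.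

Compound 3 `COc1cccc(COc2ccc3cc(C(=O)/C=C/c4ccc(C)cc4)c(=O)oc3c2)c1` has not yet been measured. It differs from compound 1 by methyl in place of methoxy on an aromatic carbon, para to a large group. Going by the values given here, no step between measured compounds bearing this change is available here. Since compound 1 sits at the limit, the change is expected to move the value by nothing beyond the scatter, in either direction, and compound 3 is expected to stay at the limit as well. Compound 3 is estimated at 100000 nM in this assay, within 30000 nM to 300000 nM. The step of a number no higher from compound 1 to compound 3 (the limit leaves the size open) is thus expected to be flat.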

Compound 3, half-maximal inhibitory concentration: > 50000 nM
Compound 3: only a limit was reported; the forecaster's own chance of this, stated with the estimate: 80%; the middle value lies beyond the limit too.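

In this assay compound 3 gives > 50000 nM, which is a limit of the assay and not a number. Going by these compounds alone, compound 1 also stands only at a limit, and no step from compound 1 to compound 3 can be read. The compounds shown leave open whether methyl in place of methoxy on an aromatic carbon shifts the value at all.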